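The source may report more compounds than this note shows. Statements on the series, on what has been measured and on what is new or still open speak of the compounds shown alone.

Compound 1 `CCCCCCCCn1cc(COC[C@@H]2OC[C@H](N)[C@@H]2O)nn1`: 28100 nM
Compound 2 `CCCCCCCn1cc(COC[C@@H]2OC[C@H](N)[C@H]2O)nn1`: > 128000 nM

Both compounds were tested in a functional assay on MCF7 cells (Homo sapiens) for antiproliferative activity, read by MTT assay, with a stated time of 48 h (on this read-out higher numbers stand for weaker inhibition and lower numbers for stronger inhibition), and only compound 1 returned a number. Compound 2 stands at a limit of the assay, > 128000 nM. Compound 3 `CCCCCCCCn1cc(COC[C@@H]2OC[C@H](N)[C@H]2O)nn1` departs from compound 2 by a single change: methyl in place of hydrogen on a saturated chain carbon, seven bonds along the chain from an aromatic nitrogen. Among the compounds with values here, no measured step shows what this change does. A moderate step towards stronger inhibition is expected, since compound 1 reaches 28100 nM. That expectation corresponds to an estimated step of an at least 2.1-fold lower number from compound 2 to compound 3 (0.32 log units; beyond the scatter). Compound 3 is estimated at 60000 nM, with an expected range of 20000 nM to 140000 nM.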

Compound 3, half-maximal inhibitory concentration: > 128000 nM
Compound 3: no number, only a limit; the forecaster's own chance of this, stated with the estimate: 35%; at least 2.1-fold (0.32 log units) between middle value and limit.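

Compound 3 also gives only a limit in this assay, > 128000 nM. Changing the configuration at one saturated ring carbon from S to R, with the octyl-length chain kept, gives an at least 4.5-fold higher number from compound 1 to compound 3 (0.65 log units; beyond the scatter), so at this chain length the stereocentre matters. What the added methyl does on the chain alone cannot be read: the limit of > 128000 nM in this assay, at which 2 of the 3 values shown sit.

As far as these compounds go, it remains open how far the chain of compound 2 would carry activity with the configuration of compound 1. From the compounds shown here alone, it also remains open how a longer chain or a terminal amine would behave at this position.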